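Notes on a 2-methoxyethoxy addition to compound 1

This account rests on a few compounds, and the source may have more. Where it says the series, first, only, none or still open, it means among the compounds named here.

Within the data shown here, compound 1 `CN(C)CCNc1n[n+]([O-])c2ccccc2[n+]1[O-]` holds the lowest of the two numbers measured so far in a functional assay on SiHa cells (Homo sapiens) for cytotoxicity, with a stated time of 4 h (a higher number here means a weaker inhibitor, a lower number a stronger inhibitor), where compound 1 gives 200 nM. The only other measured entry is compound 2 `CCCN(CCC)CCNc1n[n+]([O-])c2ccccc2[n+]1[O-]`; in this assay compound 2 gives 2000 nM. Among the measured compounds shown here, the single measured step, a 10-fold higher number from compound 1 to compound 2 (1.00 log units; beyond the scatter), changes the amine at the end of the saturated chain and leaves the fused aromatic core untouched.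

Compound 3 `COCCOc1ccc2c(c1)[n+]([O-])c(NCCN(C)C)n[n+]2[O-]` keeps the dimethylamino end of compound 1 and differs elsewhere: 2-methoxyethoxy in place of hydrogen on an aromatic carbon. For the measured compounds named here, no measured pair alters an aromatic carbon of the shared core, so the step from compound 1 to compound 2 does not bear on this change, and there is no basis in the numbers for predicting a shift in either direction. The working expectation is therefore a step of no change at the digits printed from compound 1 to compound 3 (within the scatter), meaning none beyond the scatter, held with low confidence and a wide range. Compound 3 is accordingly estimated at 200 nM, expected to fall between 50 nM and 800 nM.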

Compound 3, half-maximal inhibitory concentration in the SiHa assay: 2100 nM
Beside the measured number, compound 3's estimate is 11-fold (1.02 log units) below it, outside the stated range (above it).
By their numbers in the SiHa assay, from the lowest: compound 1; then compounds 2 and 3 (each within the scatter of the next).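

Among these compounds, compound 3 gives the first measured change on an aromatic carbon of the shared core: in the SiHa assay compound 3 gives 2100 nM, and there is an 11-fold higher number from compound 1 to compound 3 (1.02 log units; beyond the scatter) with the dimethylamino end held constant. The number at this carbon, meta to a fused ring and para to a fused ring, therefore responds to 2-methoxyethoxy in place of hydrogen, whereas the earlier step showed a response only at the amine end of the saturated chain. In a physicochemical assay for solubility, in the presence of a further agent that is not named here (a higher number here means a more soluble compound, a lower number a less soluble compound), compound 1 gives 50000000 nM and compound 3 gives 43000000 nM. In the physicochemical assay the same pair shows a 1.2-fold lower number from compound 1 to compound 3 (0.07 log units; within the scatter) as its step, so the shift beyond the scatter appears in only one of the two assays, and no supporting measurement accounts for it.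

The compounds shown do not separate the effect of occupying this carbon at all from that of the 2-methoxyethoxy group itself, a question that a small group such as fluorine or methoxy on the same carbon could address. They also leave open whether a longer ether chain, or an ethoxy chain ending in a dimethylamino group, would bring the number in the SiHa assay closer to that of compound 1 200 nM or move it further away.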